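A thiophene-bearing amine on the shared core

The source may hold more compounds than are shown below. What is called first, only, known or untested is meant among the compounds shown, and "the series" means these compounds.

Compound 1, `COC[C@H](NC1CCN(CCCc2c[nH]c3ccc(-n4cnnc4)cc23)CC1)c1ccccc1`, gives 0.9 nM in an assay on CHO cells for agonist activity at 5-hydroxytryptamine receptor 1D (Homo sapiens), read by GTPgammaS binding; a lower number here means that less compound is needed, a higher number that more compound is needed for the effect.
Compound 2, `c1cc(CNC2CCN(CCCc3c[nH]c4ccc(-n5cnnc5)cc34)CC2)co1`, gives 7.1 nM in this assay.
Compound 3, `C[C@@H](NC1CCN(CCCc2c[nH]c3ccc(-n4cnnc4)cc23)CC1)c1ccccc1`, gives 13 nM in this assay.

Compound 3 has the highest number of the three: a 14-fold higher number from compound 1 to compound 3 (1.16 log units; beyond the scatter), while a 1.8-fold higher number from compound 2 to compound 3 (0.26 log units; within the scatter). Compound 4, `CN(Cc1ccsc1)C1CCN(CCCc2c[nH]c3ccc(-n4cnnc4)cc23)CC1`, differs from compound 3 in one place: methyl((thiophen-3-yl)methyl)amino in place of (1-phenylethyl)amino on a saturated ring carbon. Two measured steps also swap the group on that amine nitrogen. One, a 7.9-fold higher number from compound 1 to compound 2 (0.90 log units; beyond the scatter), was modest. The other, a 1.8-fold higher number from compound 2 to compound 3 (0.26 log units; within the scatter), exchanged a five-membered aromatic ring for the phenyl group that compound 4 now removes again. Among the compounds with values here, no measured pair tests the added methyl on the nitrogen. Compound 4 is therefore expected to give 7 nM, with a range of 2 nM to 25 nM. That estimate means a 1.9-fold lower number from compound 3 to compound 4 (0.27 log units; within the scatter), a step expected to stay close to the scatter.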

Compound 4, half-maximal effective concentration: 4.2 nM
Compound 4: the middle estimate sits 1.7-fold (0.22 log units) above what was measured; measured number inside the range.
By their numbers in this assay, from the lowest: compound 1; then compounds 4, 2 and 3 (each within the scatter of the next, the first and the last beyond it).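

Replacing (1-phenylethyl)amino with methyl((thiophen-3-yl)methyl)amino gives a 3.1-fold lower number from compound 3 to compound 4 (0.49 log units; beyond the scatter), so this saturated ring carbon tolerates a group with no hydrogen-bond donor. Changing the furan-bearing group of compound 2 gives a 1.7-fold lower number from compound 2 to compound 4 (0.23 log units; within the scatter), while a 4.7-fold higher number from compound 1 to compound 4 (0.67 log units; beyond the scatter) leaves compound 1 with the lowest number of the four. Nothing given here explains these steps.

As far as these compounds go, compound 4 brings in the thiophene ring and the nitrogen methyl together, so their separate contributions remain unknown. A ((thiophen-3-yl)methyl)amino group without the methyl would separate them.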